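The source may report more compounds than this note shows. Statements on the series, on what has been measured and on what is new or still open speak of the compounds shown alone.

Measured so far:
compound 1 `CCCCC#Cc1nc(NCc2cccc(Br)c2)c2ncn([C@H]3[C@H](O)[C@H](O)[C@@H]4C[C@@H]43)c2n1`, 59 nM
compound 2 `CCCCC#Cc1nc(NC2CCCC2)c2ncn([C@H]3[C@H](O)[C@H](O)[C@@H]4C[C@@H]43)c2n1`, 58 nM

In an assay on RBL-2H3 cells for displacement of a labelled ligand from adenosine receptor A3 (Rattus norvegicus), with a stated time of 60 min (a higher number here means a weaker inhibitor, a lower number a stronger inhibitor), compound 2 gives 58 nM, the lowest of the two numbers, with compound 1 nearest; a 1.0-fold lower number from compound 1 to compound 2 (0.01 log units; within the scatter). Compound 3 `CCCCC#Cc1nc(NC)c2ncn([C@H]3[C@H](O)[C@H](O)[C@@H]4C[C@@H]43)c2n1` differs from compound 2 by methyl in place of cyclopentyl on a nitrogen on an aromatic ring. For the measured compounds named here, the only measured step on that nitrogen, a 1.0-fold lower number from compound 1 to compound 2 (0.01 log units; within the scatter), exchanged one large group for another without moving the number, so the step to compound 3 is expected to be a 1.0-fold higher number from compound 2 to compound 3 (0.01 log units; within the scatter), nothing beyond the scatter. Compound 3 is therefore estimated at 60 nM, with a range from 20 nM to 200 nM.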

Compound 3, inhibition constant: 231 nM
Compound 3: the middle estimate sits 3.9-fold (0.59 log units) below what was measured, and the stated range ends below it.
By their numbers in this assay, from the lowest: compounds 2 and 1 (each within the scatter of the next); then compound 3.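

In this assay the group on this nitrogen does affect the number, even though the exchange of cyclopentyl for 3-bromobenzyl did not: methyl gives a 4.0-fold higher number from compound 2 to compound 3 (0.60 log units; beyond the scatter) and also a 3.9-fold higher number from compound 1 to compound 3 (0.59 log units; beyond the scatter). Two quite different larger groups thus sit within the scatter of each other, while methyl, with its single carbon, falls short of both. Nothing available explains this loss. Still open, on these data alone, is where ethyl, cyclopropyl or a plain amino group would fall, and whether the number changes gradually or abruptly from methyl to cyclopentyl.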